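Hydroxamic Acid Head Group Carried Over to a Chloro Analogue

The source may hold more compounds than are shown below. What is called first, only, known or untested is meant among the compounds shown, and "the series" means these compounds.

Compound 1, `Nc1ccccc1NC(=O)c1ccc(CNCc2nc(-c3ccc(C(F)(F)F)cc3)no2)cc1`, gives > 10000 nM
Compound 2, `Nc1ccccc1NC(=O)c1ccc(CNCc2nc(-c3ccc(Cl)cc3)no2)cc1`, gives > 10000 nM
Compound 3, `O=C(NO)c1ccc(CNCc2nc(-c3ccc(C(F)(F)F)cc3)no2)cc1`, gives 1360 nM

Of the compounds shown here, three have been tested in an assay on isolated protein for inhibition of histone deacetylase 8 (Homo sapiens), read by fluorescence, with a stated time of 20 min; a lower number here means a stronger inhibitor, a higher number a weaker inhibitor. Compound 1 returns only a limit of the assay, > 10000 nM, not a number. Compound 2 likewise returns only a limit, > 10000 nM. Going by the values given here, compound 3 is the single compound with a real number, 1360 nM.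

Compound 3 differs from compound 1 in the head group: hydroxy in place of 2-aminophenyl on an amide-type nitrogen. That change gives an at least 7.3-fold lower number from compound 1 to compound 3 (0.86 log units; beyond the scatter). The other change, from compound 1 to compound 2, is chloro in place of trifluoromethyl on an aromatic carbon. Its size is a step that the two limits leave unreadable from compound 1 to compound 2, because the limit of > 10000 nM in this assay, at which 2 of the 3 values shown sit, hides any difference between the two.

Compound 4, `O=C(NO)c1ccc(CNCc2nc(-c3ccc(Cl)cc3)no2)cc1`, has not been measured. It differs from compound 3 by chloro in place of trifluoromethyl on an aromatic carbon. The place is the same, word for word, as in the change from compound 1 to compound 2, so this is the same change, now made on the head group of compound 3 rather than on that of compound 1.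

Among the compounds with values here, the only measured example of this change is unreadable, so the expectation for compound 4 rests mainly on compound 3 and its value 1360 nM, with the swap of trifluoromethyl for chloro expected to move the number little. The expected step from compound 3 to compound 4 is a 1.1-fold higher number from compound 3 to compound 4 (0.04 log units; within the scatter). Compound 4 is therefore estimated at 1500 nM, likely between 450 nM and 5000 nM.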

Compound 4, half-maximal inhibitory concentration: 350 nM
Estimate against measurement, compound 4: 4.3-fold (0.63 log units) above, outside the stated range (below it).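

Swapping 2-aminophenyl for hydroxy on the amide-type nitrogen carries over in direction in this assay. It gives an at least 28-fold lower number from compound 2 to compound 4 (1.45 log units; beyond the scatter) on the chloro-bearing core, as it lowered the number on the trifluoromethyl-bearing core, but whether the size carries over as well remains unsettled: the same change on two cores in this assay, an at least 7.3-fold lower number (0.86 log units; beyond the scatter) from compound 1 to compound 3 and an at least 28-fold lower number (1.45 log units; beyond the scatter) from compound 2 to compound 4; the limit leaves it open whether they differ. Chloro in place of trifluoromethyl gives a 3.9-fold lower number from compound 3 to compound 4 (0.59 log units; beyond the scatter) with the hydroxy head group, yet the same swap cannot be read with the 2-aminophenyl head group, and so nothing here shows whether this step carries over from one head group to the other, because compound 1 and compound 2 each return a limit rather than a number: the limit of > 10000 nM in this assay, at which 2 of the 4 values shown sit.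

The compounds shown leave open whether the lower number seen with chloro extends to other groups in that place, such as fluoro, bromo or methyl. They also leave open how another head group, such as a carboxylic acid, would compare with hydroxy and 2-aminophenyl, and whether either swap would behave the same way on a core with a longer chain.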